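The compounds below may be only part of what the source reports. "The series", "measured", "known", "first", "only" and "open" are said of these compounds alone.

Compound 1 `c1ccc(C(/N=C2\CCCCN2)C2CC2)cc1` and compound 3 `c1ccc(C(/N=C2\CCCCN2)c2ccco2)cc1` share one core. In a functional assay on the whole organism (plasma, strain Sprague-Dawley) with Rattus norvegicus as the target, with a stated time of 2 h, at a dose of 12.5 mg/kg by the oral route (on this read-out higher numbers stand for a stronger effect at the one dose given and lower numbers for a weaker effect), compound 1 gives 1%, and in this assay compound 3 gives 13%. The change between them, (furan-2-yl in place of cyclopropyl on a saturated chain carbon bound to an aromatic carbon and a double-bonded nitrogen), brought a number 12 percentage points higher from compound 1 to compound 3 (beyond the scatter). Compound 2 `c1ccc(C(/N=C2\CCCCCCN2)C2CC2)cc1` rests on a second core, and the difference between the two cores is not broken down here. In this assay compound 2 gives 0%, which lies within the scatter of compound 1. Compound 4 `c1ccc(C(/N=C2\CCCCCCN2)c2ccco2)cc1` carries the same change on the core of compound 2: furan-2-yl in place of cyclopropyl on a saturated chain carbon bound to an aromatic carbon and a double-bonded nitrogen. Because the earlier step was a number 12 percentage points higher from compound 1 to compound 3 (beyond the scatter), a step of about that size is expected here, namely a number 10 percentage points higher from compound 2 to compound 4 (within the scatter). Compound 4 is therefore estimated to give 10% in this assay, expected to fall between 0% and 25%.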

Compound 4, a percentage reported as inhibition, in the whole organism at one dose (the size of the read-out at that dose, not a potency): 22%
Beside the measured number, compound 4's estimate is 12 percentage points below it, within the range that was stated.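

In this assay the swap of cyclopropyl for furan-2-yl gives a number 22 percentage points higher from compound 2 to compound 4 (beyond the scatter) on the second core. The change raises the number on both cores, and the two steps cannot be told apart by size: the same change on two cores in this assay, a number 12 percentage points higher (beyond the scatter) from compound 1 to compound 3 and a number 22 percentage points higher (beyond the scatter) from compound 2 to compound 4, 10 percentage points apart, within the scatter of two such steps. So in these two pairs the change carried over from one core to the other, but two pairs cannot show that it would do so on a further core, and the read-out at one dose is not a potency and gives no reason for the rise.

Open, as far as these compounds go, is how other groups on that saturated chain carbon, such as an amine, a carboxylic acid or a longer chain, would compare with furan-2-yl. Also open is how any of these compounds would behave at other doses.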